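This account rests on a few compounds, and the source may have more. Where it says the series, first, only, none or still open, it means among the compounds named here.

Working notes on the series.

Compound 1, `COc1ccc(C(=O)Nc2cc3nc(C4CCCCC4)[nH]c3cc2N(C)C)cc1`, is the reference point. In an ADME assay on Vero cells (Chlorocebus sabaeus) for cytotoxicity, read by resazurin assay, with a stated time of 3 days (a lower number here means a stronger inhibitor, a higher number a weaker inhibitor), compound 1 returns only a limit, > 100 ug/mL. Compound 3, `COc1ccc(C(=O)Nc2cc3nc(C4CCCCC4)[nH]c3cc2N2CCCC2)cc1`, likewise sits at a limit in this assay, > 100 ug/mL. Compound 2, `O=C(Nc1cc2nc(C3CCCCC3)[nH]c2cc1N1CCCC1)c1ccc(Br)cc1`, also gives a limit, > 100 ug/mL. All three values therefore lie on one line, (the limit of > 100 ug/mL in this assay, at which 3 of the 3 values shown sit), and neither step shown can be sized: a step that the two limits leave unreadable from compound 1 to compound 3, and a step that the two limits leave unreadable from compound 2 to compound 3.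

The step to compound 4, `CN(C)c1cc2[nH]c(C3CCCCC3)nc2cc1NC(=O)c1ccc(C(C)(C)C)cc1`, is tert-butyl in place of methoxy on an aromatic carbon. No measured step touches this position; the two steps that are shown both stay unreadable between limits, so they give no size and no direction, only that nothing has yet moved off the limit. The expectation for compound 4 is therefore a step of a number no higher from compound 1 to compound 4 (the limit leaves the size open), that is, none beyond the scatter. Compound 4 is estimated at 100 ug/mL in this assay, within 50 ug/mL to 200 ug/mL, most likely reported again as a limit.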

Compound 4, half-maximal inhibitory concentration: > 100 ug/mL
Compound 4 was reported as a limit; the forecaster's own chance of this, stated with the estimate: 80%; the middle value sits exactly at the limit.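

The step from compound 1 to compound 4 cannot be read in this assay, since both values are limits: the limit of > 100 ug/mL in this assay, at which 4 of the 4 values shown sit. Whether any change among these compounds moves a value off this limit stays open, and with it the size and direction of every step.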